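The source may report more compounds than this note shows. Statements on the series, on what has been measured and on what is new or still open speak of the compounds shown alone.

Of the compounds shown here, three have so far been measured in a functional assay on Ehrlich cells (Mus musculus) for antiproliferative activity, read by trypan blue exclusion, with a stated time of 2 h, tested at 100 ug/mL; on this read-out lower numbers stand for a weaker effect and higher numbers for a stronger effect at the one concentration tested. Compound 1 `COc1ccc(C2C(C#N)=C(N)N(c3ccc(S(N)(=O)=O)cc3)C3=C2C(=O)CCC3)cc1` gives 100% in this assay. Compound 2 `N#CC1=C(N)N(c2ccc(S(N)(=O)=O)cc2)C2=C(C(=O)CCC2)C1c1ccc(Cl)cc1Cl` gives 95% in this assay. Compound 3 `N#CC1=C(N)N(c2ccc(S(N)(=O)=O)cc2)C2=C(C(=O)CCC2)C1c1c(O)ccc2ccccc12` gives 15% in this assay, the lowest of the three numbers; its nearest neighbour is compound 2 and its furthest is compound 1. The step of a number 5 percentage points lower from compound 1 to compound 2 (within the scatter) lies within the scatter, whereas the two steps into compound 3 are both large and beyond it.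

Compound 4 `N#CC1=C(N)N(c2ccc(S(N)(=O)=O)cc2)C2=C(C(=O)CCC2)C1c1ccco1` has not yet been measured. It differs from compound 3 in one place: furan-2-yl in place of 2-hydroxynaphthalen-1-yl on a saturated ring carbon. The measured steps that bear on this change are a number 85 percentage points lower from compound 1 to compound 3 (beyond the scatter) and a number 80 percentage points lower from compound 2 to compound 3 (beyond the scatter); each shows that bringing 2-hydroxynaphthalen-1-yl onto the saturated ring carbon went together with a large loss. Taking that group away again in favour of furan-2-yl is therefore expected to recover much of what was lost, although no measured compound carries furan-2-yl, so the exact size cannot be read from the data. The step of a number 60 percentage points higher from compound 3 to compound 4 (beyond the scatter) is expected to be large and upward. Compound 4 is estimated at 75%, with a range from 40% to 100%.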

Compound 4, a percentage reported as activity, at one concentration (the size of the read-out at that concentration, not a potency): 10%
For compound 4 the middle estimate is 65 percentage points above the measured one; measured number outside the range, below it.
By their numbers in this assay, from the lowest: compounds 4 and 3 (each within the scatter of the next); then compounds 2 and 1 (each within the scatter of the next).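

In this assay, the step of a number 5 percentage points lower from compound 3 to compound 4 (within the scatter) shows that 2-hydroxynaphthalen-1-yl and furan-2-yl, two groups that share little in size or ring type, cannot be told apart on this saturated ring carbon, so the earlier loss is not peculiar to 2-hydroxynaphthalen-1-yl. The furan-2-yl group also stands far from both other groups, with steps of a number 85 percentage points lower from compound 2 to compound 4 (beyond the scatter) and a number 90 percentage points lower from compound 1 to compound 4 (beyond the scatter), so among these four compounds the position separates 4-methoxyphenyl and 2,4-dichlorophenyl from 2-hydroxynaphthalen-1-yl and furan-2-yl. Nothing available here explains this division.

The compounds shown leave open what the two high-scoring groups have in common that the other two lack, and a plain phenyl, a 2-hydroxyphenyl or a thiophen-2-yl group on this carbon would help to narrow that question. They also leave open whether compounds that look alike at this one concentration would still look alike across a range of concentrations, since the read-out gives a size of effect and not a potency.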